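Trading an Aryl Methoxy Group for a Phenol

The source may report more compounds than this note shows. Statements on the series, on what has been measured and on what is new or still open speak of the compounds shown alone.

Measured so far:
- compound 1 `COc1ccc(Br)cc1CCc1c(Cl)cccc1-c1nccn1C`: in a functional assay on HEK293 cells (Homo sapiens), read by cAMP accumulation (on this read-out higher numbers stand for weaker inhibition and lower numbers for stronger inhibition), compound 1 gives 1100 nM
- compound 2 `CCC(C)n1ccnc1-c1cccc(Cl)c1CCc1cc(Br)ccc1OC`: in this assay compound 2 gives 2100 nM

Compound 1 holds the lower of the two numbers, but its nearest neighbour, compound 2, sits close by: a 1.9-fold higher number from compound 1 to compound 2 (0.28 log units; within the scatter). Compound 3 `Cn1ccnc1-c1cccc(Cl)c1CCc1cc(Br)ccc1O` differs from compound 1 by hydrogen in place of methyl on an oxygen on an aromatic ring. Among the compounds with values here, the one measured step, from compound 1 to compound 2, touches a different place, the substituent on the aromatic nitrogen, and it stayed within the scatter. Within the data shown here, no measured step speaks to the methoxy-to-hydroxy change itself. Without such evidence, the expected step of a 1.4-fold higher number from compound 1 to compound 3 (0.13 log units; within the scatter) in this assay is small, with no clear direction and broad uncertainty. For compound 3 the estimated value in this assay is 1500 nM, expected to fall between 400 nM and 6000 nM.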

Compound 3, half-maximal inhibitory concentration: 10200 nM
Beside the measured number, compound 3's estimate is 6.8-fold (0.83 log units) below it; measured number above the stated range.
By their numbers in this assay, from the lowest: compounds 1 and 2 (each within the scatter of the next); then compound 3.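

In this assay the methoxy to hydroxy change is no quiet edit: a 9.3-fold higher number from compound 1 to compound 3 (0.97 log units; beyond the scatter) and so toward weaker inhibition. The swap of methyl for sec-butyl on the aromatic nitrogen gave a 1.9-fold higher number from compound 1 to compound 2 (0.28 log units; within the scatter) and stayed within the scatter, whereas this change on the oxygen lies beyond it, so the number responds to the methyl on this oxygen in a way the earlier pair could not reveal. No measurement shown here accounts for the size of this step.

Going by these compounds, whether the same rise appears when sec-butyl sits on the aromatic nitrogen remains open. Also open, on these data alone, is what an ethoxy group or an amine would give at this place on the aromatic ring, and so whether the methyl itself matters or any group larger than hydrogen would serve.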